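The compounds below may be only part of what the source reports. "The series", "measured", "known", "first", "only" and "open" are said of these compounds alone.

Measured so far:
- compound 1 `C=C1[C@@H](OC(C)=O)C[C@@H]2[C@](C)(COC=O)[C@H](OC(C)=O)CC[C@@]2(C)[C@@H]1C[C@@H](Nc1ccccc1F)C1=CCOC1=O`: 16400 nM
- compound 2 `C=C1[C@@H](OC(C)=O)C[C@@H]2[C@](C)(COC=O)[C@H](OC(C)=O)CC[C@@]2(C)[C@@H]1C/C=C1/C(=O)OC[C@H]1OC(C)=O`: 12900 nM
- compound 3 `C=C1[C@@H](OC(C)=O)C[C@@H]2[C@](C)(CO[Si](C)(C)C(C)(C)C)[C@H](OC(C)=O)CC[C@@]2(C)[C@@H]1C[C@@H](Nc1ccccc1F)C1=CCOC1=O`: 2930 nM

In a functional assay on MCF7 cells (Homo sapiens) for cytotoxicity, read by sulforhodamine B assay (a higher number here means a weaker inhibitor, a lower number a stronger inhibitor), compound 3 gives 2930 nM, the lowest of the three numbers. Next in the series is compound 4 `C=C1[C@@H](OC(C)=O)C[C@@H]2[C@](C)(CO[Si](C)(C)C(C)(C)C)[C@H](OC(C)=O)CC[C@@]2(C)[C@@H]1C[C@@H](Nc1cccc(OC)c1)C1=CCOC1=O`, which differs from compound 3 by 3-methoxyphenyl in place of 2-fluorophenyl on an amine nitrogen.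

Among the compounds with values here, the only measured step between single-place analogues is a 5.6-fold lower number from compound 1 to compound 3 (0.75 log units; beyond the scatter). That change lies on an oxygen on a saturated carbon, not on the amine nitrogen, so it gives no direct measure for this swap. Within the data shown here, compound 2 does not carry the (2-fluorophenyl)amino group, and no measured pair varies the group on that nitrogen. With no evidence for a direction, no change beyond the scatter is expected, and the estimated step is a 1.1-fold higher number from compound 3 to compound 4 (0.05 log units; within the scatter). The range is kept wide because the data do not test this position. For compound 4 the expected value is 3300 nM, with an estimated range of 1300 nM to 8500 nM.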

Compound 4, half-maximal inhibitory concentration: 28100 nM
For compound 4 the middle estimate is 8.5-fold (0.93 log units) below the measured one; measured number outside the range, above it.
By their numbers in this assay, from the lowest: compound 3; then compounds 2, 1 and 4 (each within the scatter of the next, the first and the last beyond it).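

In this assay, within the data shown here, the group on the amine nitrogen proves able to move the number: 3-methoxyphenyl in place of 2-fluorophenyl gives a 9.6-fold higher number from compound 3 to compound 4 (0.98 log units; beyond the scatter), the first measured change at this position. The swap replaces both the substituent and its numbered place on the phenyl ring, so this single step cannot assign the loss to either change. No measurement shown accounts for the step.

An unsubstituted phenyl, 2-methoxyphenyl or 3-fluorophenyl on this nitrogen would separate the effect of the substituent from that of its place on the ring, and a saturated group such as cyclohexyl would test whether an aromatic ring is needed there at all. Also open, from the compounds shown here alone, is whether the same swap gives a similar step with the oxygen substituent of compound 1.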